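A Methyl Ketone in Place of the Terminal Amide

A few compounds are considered here, and "the series" means these few. Any claim that something is new, unique, unknown or untested is made for them only; others in the source may bear on it.

Compound 1 `NC(=O)C(=O)NCCCCCC(=O)Nc1ccccc1` carries a (carbamoylcarbonyl)amino group at one end of a saturated chain and an anilide at the other. In a functional assay on HCT-116 cells (Homo sapiens) for inhibition, read by colorimetric assay, with a stated time of 3 days (a higher number here means a weaker inhibitor, a lower number a stronger inhibitor), compound 1 gives only a limit rather than a number, > 100000 nM. That limit, (the limit of > 100000 nM in this assay, at which 1 of the 2 values shown sits), places compound 1 at the weak end of what is shown. Among the compounds with values here, the only other measured compound, compound 2 `O=C(CCCCCCNC(=O)C(O)(O)C(F)(F)F)Nc1ccc(F)cc1`, differs in several places at once and gives 7570 nM in this assay.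

Compound 3 `CC(=O)C(=O)NCCCCCCC(=O)Nc1ccccc1` is the next step: ((acetylcarbonyl)amino)methyl in place of (carbamoylcarbonyl)amino on a saturated chain carbon, five bonds along the chain from a carbonyl carbon. Within the data shown here, with no measured pair showing the effect of this exchange, the step from compound 1 to compound 3 in this assay is expected to be no larger than a small shift toward stronger inhibition, an at least 1.6-fold lower number from compound 1 to compound 3 (0.22 log units; that floor lies within the scatter), and may again end at a limit. Compound 3 is therefore estimated at 60000 nM, within a range of 8000 nM to 100000 nM.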

Compound 3, half-maximal inhibitory concentration: > 100000 nM
Compound 3 ended at the assay's limit (the forecaster's own chance of this, stated with the estimate: 50%); at least 1.6-fold (0.22 log units) between middle value and limit.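

Compound 1 and compound 3 both end at a limit rather than a number, so no step between them can be read: the limit of > 100000 nM in this assay, at which 2 of the 3 values shown sit.

As far as these compounds go, whether ((acetylcarbonyl)amino)methyl in place of (carbamoylcarbonyl)amino changes inhibition at all in this assay, and by how much, stays open.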